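A Pyridinyl Arm on the Nitro-Bearing Core

This account rests on a few compounds, and the source may have more. Where it says the series, first, only, none or still open, it means among the compounds named here.

The measured compounds are:
compound 1, `Cc1nc(O)c(C#N)c(NCc2ccncc2)n1`, 4400 nM
compound 2, `CCNc1nc(C)nc(O)c1C#N`, 2600 nM
compound 3, `CCNc1nc(C)nc(O)c1[N+](=O)[O-]`, 25000 nM

Three compounds have been run in a functional assay (muscle tissue) with Felis catus as the target; a higher number here means that more compound is needed for the effect, a lower number that less compound is needed. Compound 3 stands highest of the three: the change of nitro in place of cyano gives a 9.6-fold higher number from compound 2 to compound 3 (0.98 log units; beyond the scatter), and against compound 1 the gap is also beyond the scatter, compound 1 giving 4400 nM where compound 3 gives 25000 nM.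

Compound 4, `Cc1nc(O)c([N+](=O)[O-])c(NCc2cccnc2)n1`, is the next compound. It differs from compound 3 in one place: pyridin-3-yl in place of methyl on a saturated chain carbon bound to a nitrogen on an aromatic ring.

For the measured compounds named here, one measured step bears on this change. Methyl in place of pyridin-4-yl on the same kind of carbon gave a 1.7-fold lower number from compound 1 to compound 2 (0.23 log units; within the scatter), a step within the scatter. Compound 4 makes the opposite kind of exchange, bringing in a pyridin-3-yl rather than the pyridin-4-yl of compound 1, on the nitro-bearing core of compound 3. Nothing measured separates the two pyridinyl groups. Compound 4 is therefore expected to show a 1.4-fold higher number from compound 3 to compound 4 (0.15 log units; within the scatter), a step not beyond the scatter, with the number if anything slightly higher. Compound 4 is estimated at 35000 nM, with a range from 12000 nM to 100000 nM.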

Compound 4, half-maximal effective concentration: 5300 nM
For compound 4 the middle estimate is 6.6-fold (0.82 log units) above the measured one; measured number below the stated range.
By their numbers in this assay, from the lowest: compounds 2, 1 and 4 (each within the scatter of the next, the first and the last beyond it); then compound 3.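

In this assay the result is a 4.7-fold lower number from compound 3 to compound 4 (0.67 log units; beyond the scatter) and so shows that pyridin-3-yl in place of methyl, on a saturated chain carbon bound to a nitrogen on an aromatic ring, can move the number beyond the scatter on the nitro-bearing core. The earlier exchange at this place, a 1.7-fold lower number from compound 1 to compound 2 (0.23 log units; within the scatter) on the nitrile-bearing core, stayed within the scatter, so the position proves responsive on one core and not on the other. That contrast is not clean, since it also involves pyridin-3-yl on one side and pyridin-4-yl on the other. Nothing measured here accounts for the step.

From the compounds shown here alone, whether the two pyridinyl groups give different numbers on a single core remains open, as does how nitro and cyano compare when the chain carries a pyridinyl group. Going by these compounds, it is also open whether a phenyl ring or a longer alkyl chain at the same place would give the same shift as pyridin-3-yl.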